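Ethyl on the amide-type nitrogen of compound 2

The compounds below may be only part of what the source reports. "The series", "measured", "known", "first", "only" and "open" are said of these compounds alone.

Working notes on the series in a functional assay on SMMC-7721 cells (Homo sapiens) for cytotoxicity, read by MTT assay, with a stated time of 72 h; a higher number here means a weaker inhibitor, a lower number a stronger inhibitor. Compound 1 `CCNC(=O)N1CCN(C(=S)SCc2cn(Cc3ccc(C)cc3)nn2)CC1` gives > 128000 nM, which is a limit of the assay and not a number. Compound 2 `COc1cc(Cn2cc(CSC(=S)N3CCN(C(N)=O)CC3)nn2)cc(OC)c1OC` gives > 128000 nM, again a limit rather than a measured value. Compound 2 therefore stands at the limit of > 128000 nM in this assay, at which 2 of the 2 values shown sit, with nothing in the set beyond that limit. Compound 3 `CCNC(=O)N1CCN(C(=S)SCc2cn(Cc3cc(OC)c(OC)c(OC)c3)nn2)CC1` is not yet measured in this assay. It differs from compound 2 in one place: ethyl in place of hydrogen on an amide-type nitrogen, carbamoyl to ethylcarbamoyl. Compound 1 already carries this ethylcarbamoyl group and also sits at the limit. No step beyond the scatter is expected from compound 2 to compound 3, the expected change being a step that the limit leaves unreadable from compound 2 to compound 3. Compound 3 is expected at 150000 nM, within 60000 nM to 400000 nM, and most likely reported again only as a limit.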

Compound 3, half-maximal inhibitory concentration: > 128000 nM
Compound 3 was reported as a limit; the forecaster's own chance of this, stated with the estimate: 85%; the middle value does not contradict the limit.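

No new step can be read from compound 2 to compound 3 in this assay, because both are reported only as a limit of the assay: the limit of > 128000 nM in this assay, at which 3 of the 3 values shown sit.

The compounds shown leave open whether ethyl in place of hydrogen on the amide-type nitrogen changes the read-out at all.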